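Shortening the amine side chain on the compound 1 core

The compounds below may be only part of what the source reports. "The series", "measured", "known", "first", "only" and "open" are said of these compounds alone.

Among the compounds with values here, compound 1 `CC(C)NCCCOc1cccc2ccccc12` gives 7660 nM in a functional assay for agonist activity at 5-hydroxytryptamine receptor 1B (Homo sapiens) (on this read-out lower numbers stand for stronger inhibition and higher numbers for weaker inhibition), and stands as the higher of the two numbers measured so far. Compound 2 `CNCCCOc1ccccc1`, built on a smaller core with a methylamino chain, gives 3450 nM in this assay, and its number lies beyond the scatter from that of compound 1. Compound 3 `CNCCOc1cccc2ccccc12` keeps the core of compound 1 and carries the change (methylamino in place of (isopropylamino)methyl on a saturated chain carbon, two bonds along the chain from an oxygen on an aromatic ring). Within the data shown here, no measured pair shows this exact step, so the expectation rests on compound 2 alone, which with a methylamino end gives 3450 nM. A modest step toward a lower number is expected, though it may not clear the scatter. Compound 3 is therefore estimated at 3000 nM in this assay, within 700 nM to 12000 nM, an expected step of a 2.6-fold lower number from compound 1 to compound 3 (0.41 log units; beyond the scatter).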

Compound 3, inhibition constant: 26 nM
The estimate for compound 3 lay 120-fold (2.06 log units) above the measured number; the whole stated range lies above it.
By their numbers in this assay, from the lowest: compound 3; then compound 2; then compound 1.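

On the core of compound 1, the position on a saturated chain carbon, two bonds along the chain from an oxygen on an aromatic ring, proves highly sensitive in this assay: methylamino in place of (isopropylamino)methyl gives a 290-fold lower number from compound 1 to compound 3 (2.47 log units; beyond the scatter). The core of compound 1 therefore does not fix a high number by itself, and the side chain alone can move the read-out this far. The change takes the group from 5 heavy atoms to 2, with the same count of hydrogen-bond donors and acceptors.

Open, going by these compounds, is whether the chain shortening or the swap of the isopropyl end for methyl carries the step, and how an ethylamino or a dimethylamino end would read on this chain. Nothing available here explains the size of the step.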